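A few compounds are considered here, and "the series" means these few. Any claim that something is new, unique, unknown or untested is made for them only; others in the source may bear on it.

In a functional assay on NCI-H460 cells (Homo sapiens) for cytotoxicity, read by MTT assay, with a stated time of 72 h (a higher number here means a weaker inhibitor, a lower number a stronger inhibitor), compound 1 `CC(C)(C)c1[nH]cnc1/C=c1\[nH]c(=O)/c(=C/c2cccc(Oc3ccc(F)cc3)c2)[nH]c1=O` gives 4 nM and compound 2 `O=c1[nH]/c(=C\c2c[nH]cn2)c(=O)[nH]/c1=C\c1cccc(Oc2ccc(F)cc2)c1` gives 479 nM, so compound 2 holds the higher of the two numbers and is the weaker inhibitor of the pair. The next change leads to compound 3 `O=c1[nH]/c(=C\c2ccccn2)c(=O)[nH]/c1=C\c1cccc(Oc2ccc(F)cc2)c1`: pyridin-2-yl in place of 1H-imidazol-4-yl on a double-bonded chain carbon bound to an aromatic carbon. Going by the values given here, only one measured step touches this part of the structure: a 120-fold higher number from compound 1 to compound 2 (2.08 log units; beyond the scatter). That step is large, but it is hydrogen in place of tert-butyl and not an exchange of the group itself, so it gives no direction here. Among the compounds with values here, no measured compound carries pyridin-2-yl. No shift beyond the scatter is therefore expected in this assay, though confidence is low. The expected step is a 1.0-fold higher number from compound 2 to compound 3 (0.02 log units; within the scatter). For compound 3 the estimated value is 500 nM, with an expected range of 100 nM to 2500 nM.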

Compound 3, half-maximal inhibitory concentration: 49.1 nM
Compound 3: the middle estimate sits 10-fold (1.01 log units) above what was measured, outside the stated range (below it).
By their numbers in this assay, from the lowest: compound 1; then compound 3; then compound 2.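

In this assay, the ring on a double-bonded chain carbon bound to an aromatic carbon matters in its own right, not only through tert-butyl: pyridin-2-yl in place of 1H-imidazol-4-yl gives a modest drop in the number (a 9.8-fold lower number from compound 2 to compound 3 (0.99 log units; beyond the scatter)). This exchange needs no tert-butyl, yet it does not match the 5-(tert-butyl)-1H-imidazol-4-yl group of compound 1, and the step to pyridin-2-yl remains large (a 12-fold higher number from compound 1 to compound 3 (1.09 log units; beyond the scatter)). No measured evidence on hand accounts for the difference between these rings.

Still open, from the compounds shown here alone, is whether tert-butyl on the pyridin-2-yl ring would lower the number as it does on 1H-imidazol-4-yl. Going by these compounds, the reading of a plain phenyl ring or of pyridin-3-yl at this place also remains open.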